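A few compounds are considered here, and "the series" means these few. Any claim that something is new, unique, unknown or untested is made for them only; others in the source may bear on it.

Of the compounds shown here, two on a shared core have been tested in an ADME assay on H1-HeLa cells (Homo sapiens) for cytotoxicity; a lower number here means that less compound is tolerated, a higher number that more compound is tolerated. Compound 1, `Cc1nc(NC(=O)C(C)(C)CC(F)(F)F)sc1-c1ccc(N)nc1`, gives in this assay only a limit, > 66000 nM. Compound 2, `Cc1nc(NC(=O)C2(C)CCCCC2)sc1-c1ccc(N)nc1`, gives in this assay 39000 nM. Within the data shown here, compound 2 thus holds the only number in this assay, the other value shown being (the limit of > 66000 nM in this assay, at which 1 of the 2 values shown sits). Compound 3, `CO[C@H]1CC[C@@H](C(=O)Nc2nc(C)c(-c3ccc(N)nc3)s2)CC1`, differs from compound 2 at the carbonyl carbon: 4-methoxycyclohexyl in place of 1-methylcyclohexyl on a carbonyl carbon. Among the measured compounds shown here, one measured step bears on this change, an at least 1.6-fold lower number from compound 1 to compound 2 (0.22 log units; that floor lies within the scatter), which also exchanges the group on the carbonyl carbon and whose floor lies within the scatter. For the measured compounds named here, with that single step as the only guide, no movement beyond the scatter is expected in this assay, and the estimated step of a 1.0-fold higher number from compound 2 to compound 3 (0.01 log units; within the scatter) is expected to be small. Compound 3 is accordingly estimated at 40000 nM, with a range from 15000 nM to 100000 nM.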

Compound 3, half-maximal cytotoxic concentration in the H1-HeLa assay: 22000 nM
Compound 3: the middle estimate sits 1.8-fold (0.26 log units) above what was measured; the range from low to high includes it.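

In the H1-HeLa assay the exchange of 1-methylcyclohexyl for 4-methoxycyclohexyl on a carbonyl carbon gives a 1.8-fold lower number from compound 2 to compound 3 (0.25 log units; within the scatter), so this assay does not separate the two compounds, whereas a physicochemical assay for lipophilicity, at pH 7.4 (a lower number here means a more polar compound, a higher number a more lipophilic compound), does: the measured distribution coefficient of compound 2, 3.8, and of compound 3, 2.8, a number 1.00 log units lower (beyond the scatter) In the physicochemical assay compound 2 gives 3.8 and compound 3 gives 2.8. In the H1-HeLa assay compound 1 gives only a limit, > 66000 nM. Even so, the H1-HeLa assay reads an at least 3.0-fold lower number from compound 1 to compound 3 (0.47 log units; beyond the scatter), the first step at this position that lies beyond the scatter.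

The compounds shown leave open whether the oxygen of the methoxy group or the loss of the ring methyl accounts for the step from compound 2 to compound 3, and how the other stereoisomer of the 4-methoxycyclohexyl group would read. They also leave open how a hydroxyl or an amine at that ring position would stand in the H1-HeLa assay.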